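A few compounds are considered here, and "the series" means these few. Any claim that something is new, unique, unknown or untested is made for them only; others in the source may bear on it.

Of the compounds shown here, three sharing one core have been measured so far in a functional assay on DU-145 cells (Homo sapiens) for inhibition, read by trypan blue exclusion, with a stated time of 72 h (a higher number here means a weaker inhibitor, a lower number a stronger inhibitor), and differ only in the group on a nitrogen on an aromatic ring. Compound 1 `Cn1c(=O)c(S(=O)(=O)c2ccc(F)cc2F)cc2cnc(Nc3ccc4[nH]c(C(=O)O)cc4c3)nc21` carries 2-carboxy-1H-indol-5-yl and gives 10000 nM as its half-maximal inhibitory concentration. Compound 2 `Cn1c(=O)c(S(=O)(=O)c2ccc(F)cc2F)cc2cnc(Nc3ccc4sccc4c3)nc21` carries 1-benzothiophen-5-yl and gives 500 nM on the same read-out. Compound 3 `Cc1cc2cc(Nc3ncc4cc(S(=O)(=O)c5ccc(F)cc5F)c(=O)n(C)c4n3)ccc2[nH]1` carries 2-methyl-1H-indol-5-yl and gives 750 nM on that read-out too. There is a 1.5-fold higher number from compound 2 to compound 3 (0.18 log units; within the scatter) here, so compound 3 stands level with compound 2, while a 20-fold lower number from compound 1 to compound 2 (1.30 log units; beyond the scatter) and a 13-fold lower number from compound 1 to compound 3 (1.12 log units; beyond the scatter) set compound 1 far apart from both.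

Compound 4 `Cn1c(=O)c(S(=O)(=O)c2ccc(F)cc2F)cc2cnc(Nc3ccc4c(c3)C(=O)C(=O)N4)nc21` changes the group of compound 3 at that same nitrogen, and the difference is a group of 11 heavy atoms (8 carbon, 1 nitrogen, 2 oxygen; one five-membered non-aromatic ring with 1 hetero atom, one six-membered aromatic ring of carbon only) in place of a group of 10 heavy atoms (9 carbon, 1 nitrogen; one five-membered aromatic ring with 1 hetero atom, one six-membered aromatic ring of carbon only), on a nitrogen on an aromatic ring in all. A five-membered non-aromatic ring replaces the five-membered aromatic ring, and hydrogen-bond acceptors enter. Going by the values given here, of the measured groups, only that of compound 1 holds oxygen, and compound 1 gives 10000 nM in this assay as the one high number. That is a single case, so only a moderate rise is expected, well short of the size of a 13-fold lower number from compound 1 to compound 3 (1.12 log units; beyond the scatter) in that comparison. The expected change is a 2.7-fold higher number from compound 3 to compound 4 (0.43 log units; beyond the scatter) overall. For compound 4 the estimate is 2000 nM with an expected range of 500 nM to 8000 nM on repeated measurement.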

Compound 4, half-maximal inhibitory concentration: 75000 nM
Compound 4: the middle estimate sits 38-fold (1.57 log units) below what was measured; measured number above the stated range.
By their numbers in this assay, from the lowest: compounds 2 and 3 (each within the scatter of the next); then compound 1; then compound 4.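

At this nitrogen, the group of compound 4, with its non-aromatic five-membered ring and two hydrogen-bond acceptors, does far worse in this assay than the aromatic groups without oxygen, with a 100-fold higher number from compound 3 to compound 4 (2.00 log units; beyond the scatter) and a 150-fold higher number from compound 2 to compound 4 (2.18 log units; beyond the scatter). Going by these compounds alone, it also goes past the carboxy-bearing group, with a 7.5-fold higher number from compound 1 to compound 4 (0.88 log units; beyond the scatter), so compound 4 is now the weakest of the four and a carboxy group is not needed for a high number here; across these compounds, the two groups holding oxygen give the high numbers, and no compound goes against that. Nothing available explains why this change costs so much.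

The step from compound 3 to compound 4 changes the ring and brings in oxygen together, so these compounds cannot show which of the two matters. A five-membered non-aromatic ring holding only carbon and nitrogen, or a hydroxymethyl group in place of the methyl of compound 3, would help to separate the two.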